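Notes on the step from compound 3 to compound 4

The compounds below may be only part of what the source reports. "The series", "measured", "known", "first", "only" and "open" are said of these compounds alone.

Measured in a functional assay on MCF7 cells (Homo sapiens) for antiproliferative activity, read by MTT assay, with a stated time of 24 h; a higher number here means a weaker inhibitor, a lower number a stronger inhibitor:
- compound 1 `CCN(CC)CCNC(=O)c1ccc(C(CC)(CC)c2ccc(OCS(=O)(=O)c3ccccc3)c(C)c2)n1CC`: 4680 nM
- compound 2 `CCn1c(C(=O)NCCO)ccc1C(CC)(CC)c1ccc(OCS(=O)(=O)c2ccccc2)c(C)c1`: 15500 nM
- compound 3 `CCn1c(C(=O)N[C@H](C)CO)ccc1C(CC)(CC)c1ccc(OCS(=O)(=O)c2ccccc2)c(C)c1`: 10600 nM

Compound 3 lies within the scatter of compound 2, while a 2.3-fold higher number from compound 1 to compound 3 (0.36 log units; beyond the scatter) is modest and beyond the scatter. Compound 4 `CCn1c(C(=O)N[C@@H](CO)C(C)C)ccc1C(CC)(CC)c1ccc(OCS(=O)(=O)c2ccccc2)c(C)c1` differs from compound 3 by isopropyl in place of methyl on a saturated chain carbon bound to an amide-type nitrogen and a saturated chain carbon. Within the data shown here, the one measured change at this place is a 1.5-fold lower number from compound 2 to compound 3 (0.17 log units; within the scatter), methyl in place of hydrogen, and it stays within the scatter. On that single precedent, no step beyond the scatter is expected in this assay, with the estimated change being a 1.2-fold lower number from compound 3 to compound 4 (0.07 log units; within the scatter) in either case. The estimate for compound 4 is 9000 nM (range 4000 nM to 20000 nM).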

Compound 4, half-maximal inhibitory concentration: 18800 nM
Compound 4: middle estimate off by 2.1-fold (0.32 log units), on the low side; the range from low to high includes it.
By their numbers in this assay, from the lowest: compound 1; then compounds 3, 2 and 4 (each within the scatter of the next).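

In this assay, with isopropyl in place of methyl on this saturated chain carbon, a 1.8-fold higher number from compound 3 to compound 4 (0.25 log units; within the scatter) stays within the scatter, and with isopropyl in place of hydrogen, a 1.2-fold higher number from compound 2 to compound 4 (0.08 log units; within the scatter) stays there too. Hydrogen, methyl and isopropyl at this place therefore give no step beyond the scatter. Against 2-(diethylamino)ethyl on the amide-type nitrogen, a 4.0-fold higher number from compound 1 to compound 4 (0.60 log units; beyond the scatter) is modest and beyond the scatter. Open, on these data alone, is whether benzyl or a carboxylic acid on this carbon changes the number beyond the scatter, and whether an amine in place of the hydroxy group on the 1-(hydroxymethyl)-2-methylpropyl chain does. No evidence is available on what lies behind these numbers.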